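Varying the Aryl Group on the Imine-Linked Purine Series

The source may hold more compounds than are shown below. What is called first, only, known or untested is meant among the compounds shown, and "the series" means these compounds.

Compound 1 `O=C1Nc2ccccc2/C1=N\c1nc(NC2CC2)c2ncn(C3C=CC(CO)C3)c2n1`: 48000 nM
Compound 2 `Cc1ccc(/C=N/c2nc(NC3CC3)c3ncn(C4C=CC(CO)C4)c3n2)cc1`: > 100000 nM (a limit of the assay)
Compound 3 `O=[N+]([O-])c1ccccc1/C=N/c1nc(NC2CC2)c2ncn(C3C=CC(CO)C3)c2n1`: 13000 nM

All three were tested in a functional assay on CCRF-CEM cells (Homo sapiens) for cytotoxicity; a higher number here means that more compound is tolerated, a lower number that less compound is tolerated. Compound 3 gives the lowest of the two plain numbers; compound 1 sits above it, beyond the scatter. For compound 2 the assay reports only a limit. Within the data shown here, the one measured change at this position is an at least 7.6-fold lower number from compound 2 to compound 3 (0.88 log units; beyond the scatter). Compound 4 `CN(C)c1ccc(/C=N/c2nc(NC3CC3)c3ncn(C4C=CC(CO)C4)c3n2)cc1` differs from compound 3 by 4-(dimethylamino)phenyl in place of 2-nitrophenyl on a carbon with a double bond to nitrogen. This undoes the nitro-to-aryl step and installs a para-substituted phenyl, as in compound 2, so a step back toward higher numbers is expected: a 4.6-fold higher number from compound 3 to compound 4 (0.66 log units; beyond the scatter). Compound 4 is therefore estimated at 60000 nM, within 20000 nM to 100000 nM.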

Compound 4, half-maximal cytotoxic concentration: > 100000 nM
Compound 4: no number, only a limit (the forecaster's own chance of this, stated with the estimate: 35%); at least 1.6-fold (0.22 log units) between middle value and limit.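

Putting 4-(dimethylamino)phenyl in place of 2-nitrophenyl on the carbon with a double bond to nitrogen gives an at least 7.6-fold higher number from compound 3 to compound 4 (0.88 log units; beyond the scatter), which is a second step of this kind at this position. Compound 3 now stands alone among the three compounds with a substituted phenyl here, since compound 2 and compound 4 both reach only a limit of the assay.

Open, on these data alone, is whether 4-nitrophenyl or 2-aminophenyl would behave like 2-nitrophenyl. The step from compound 2 to compound 4 cannot be read, as both values rest on the same limit: the limit of > 100000 nM in this assay, at which 2 of the 4 values shown sit.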